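A few compounds are considered here, and "the series" means these few. Any claim that something is new, unique, unknown or untested is made for them only; others in the source may bear on it.

For the measured compounds named here, these are the values measured so far in a functional assay on MCF7 cells (Homo sapiens) for inhibition, read by sulforhodamine B assay, with a stated time of 48 h, tested at 50 uM (on this read-out higher numbers stand for more inhibition of growth at the one concentration tested and lower numbers for less inhibition of growth), for three compounds that differ only in one group.

Compound 1 `COc1ccc([C@@H]2C/C(=N/OCc3cn(-c4cccc(CO)c4)nn3)c3cc(CC=C(C)C)c(OC)cc3O2)cc1` gives 42% in this test
Compound 2 `COc1ccc([C@@H]2C/C(=N/OCc3cn(-c4ccccc4CO)nn3)c3cc(CC=C(C)C)c(OC)cc3O2)cc1` gives 100% in this test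
Compound 3 `COc1ccc([C@@H]2C/C(=N/OCc3cn(-c4ccc(NC(C)=O)cc4)nn3)c3cc(CC=C(C)C)c(OC)cc3O2)cc1` gives 0% in this test

Compound 3 stands lowest of the three at 0% on this scale. The next compound, compound 4 `COc1ccc([C@@H]2C/C(=N/OCc3cn(-c4cccnc4Cl)nn3)c3cc(CC=C(C)C)c(OC)cc3O2)cc1`, keeps the shared core but changes the group on the aromatic nitrogen in this way: 2-chloropyridin-3-yl in place of 4-acetamidophenyl on an aromatic nitrogen (2-chloropyridin-3-yl in place of 4-acetamidophenyl). Going by the values given here, no measured compound carries the new group, so the evidence is indirect. Three measured steps swap groups at this same place: a number 42 percentage points lower from compound 1 to compound 3 (beyond the scatter) and a number 100 percentage points lower from compound 2 to compound 3 (beyond the scatter) and also a number 58 percentage points higher from compound 1 to compound 2 (beyond the scatter) in the same test. All three are large, so a big change is plausible, but its size is hard to foresee. Compound 3 lies under both other compounds, with the step of a number 100 percentage points lower from compound 2 to compound 3 (beyond the scatter) as the widest gap, so a rise is expected. The expected change is a number 40 percentage points higher from compound 3 to compound 4 (beyond the scatter) as an estimate. For compound 4 the estimated value is 40% with an expected range from 5% to 90% in this assay when measured.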

Compound 4, percent growth inhibition at one concentration: 35%
For compound 4 the middle estimate is 5 percentage points above the measured one, and the stated range covers the measured number.
By their numbers in this assay, from the lowest: compound 3; then compounds 4 and 1 (each within the scatter of the next); then compound 2.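

In this assay, for the compounds shown here, the swap to 2-chloropyridin-3-yl, the first group here with a hetero atom in its six-membered aromatic ring, gives a number 35 percentage points higher from compound 3 to compound 4 (beyond the scatter). The same group falls well short of 2-(hydroxymethyl)phenyl, with a number 65 percentage points lower from compound 2 to compound 4 (beyond the scatter), while it cannot be told apart from 3-(hydroxymethyl)phenyl, with a number 7 percentage points lower from compound 1 to compound 4 (within the scatter). The leaving 4-acetamidophenyl has a hydrogen-bond donor and the entering group has none, so a donor on this aromatic group is not needed for partial inhibition at this place.

No measurement shown explains why these groups differ. Still open, on these data alone, are what the chlorine alone contributes and how an amine or a carboxylic acid on the phenyl ring would read in this test.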